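Series notes: side-chain variation on the shared core

A few compounds are considered here, and "the series" means these few. Any claim that something is new, unique, unknown or untested is made for them only; others in the source may bear on it.

Measured so far:
compound 1 `C[C@H](O)Cc1cc(-c2ccnc3[nH]nc(C(F)(F)F)c23)cc(C2(C#N)CC2)c1` — 51 nM
compound 2 `N#CC1(c2cc(CC(O)C(F)(F)F)cc(-c3ccnc4[nH]nc(C(F)(F)F)c34)c2)CC1` — 267 nM

In an assay on isolated protein for inhibition of protein kinase C epsilon type (Homo sapiens), read by coupled enzyme assay (a lower number here means a stronger inhibitor, a higher number a weaker inhibitor), compound 2 gives 267 nM, the highest of the two numbers; the nearest is compound 1, with a 5.2-fold higher number from compound 1 to compound 2 (0.72 log units; beyond the scatter). Compound 3 `N#CC1(c2cc(CC(=O)O)cc(-c3ccnc4[nH]nc(C(F)(F)F)c34)c2)CC1` differs from compound 2 by carboxy in place of 2,2,2-trifluoro-1-hydroxyethyl on a saturated chain carbon bound to an aromatic carbon. Among the measured compounds shown here, no measured step covers this change; the only one on record, a 5.2-fold higher number from compound 1 to compound 2 (0.72 log units; beyond the scatter), concerns a different exchange at the same place and gives little guidance. The expectation for compound 3 is therefore a step of a 1.5-fold higher number from compound 2 to compound 3 (0.18 log units; within the scatter), with wide uncertainty. Compound 3 is estimated at 400 nM, between 80 nM and 2000 nM.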

Compound 3, inhibition constant: 446 nM
Estimate against measurement, compound 3: 1.1-fold (0.05 log units) below; measured number inside the range.
By their numbers in this assay, from the lowest: compound 1; then compounds 2 and 3 (each within the scatter of the next).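

In this assay carboxy and 2,2,2-trifluoro-1-hydroxyethyl, on a saturated chain carbon bound to an aromatic carbon, are not separated (a 1.7-fold higher number from compound 2 to compound 3 (0.22 log units; within the scatter)). Against the 1-hydroxyethyl of compound 1, carboxy gives a step beyond the scatter (an 8.7-fold higher number from compound 1 to compound 3 (0.94 log units; beyond the scatter)), so both exchanges at this place now read beyond the scatter from compound 1. No evidence on hand accounts for these steps.

The compounds shown leave open how an amine, a primary amide or a longer chain carrying the hydroxyl would read at this place. They also leave open whether any group here gives a lower number than compound 1.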